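One more chain carbon on compound 3

This account rests on a few compounds, and the source may have more. Where it says the series, first, only, none or still open, it means among the compounds named here.

Measured in a functional assay for inhibition, with Homo sapiens as the target (on this read-out higher numbers stand for weaker inhibition and lower numbers for stronger inhibition), so far:
- compound 1 `O=C(NC[C@H](NS(=O)(=O)c1ccccc1)C(=O)O)c1cc2cc(OCC3CCNCC3)ccc2[nH]1` gives 13 nM
- compound 2 `O=C(NC[C@H](NS(=O)(=O)c1ccccc1)C(=O)O)c1cc2cc(OCCC3CCNCC3)ccc2[nH]1` gives 8 nM
- compound 3 `Cn1c(C(=O)NC[C@H](NS(=O)(=O)c2ccccc2)C(=O)O)cc2cc(OCC3CCNCC3)ccc21` gives 15 nM

The three values lie within the scatter of one another, so compound 3 stands level with both neighbours on these numbers. Compound 4 `Cn1c(C(=O)NC[C@H](NS(=O)(=O)c2ccccc2)C(=O)O)cc2cc(OCCC3CCNCC3)ccc21` has not yet been measured. It differs from compound 3 in one place, as follows: (piperidin-4-yl)methyl in place of piperidin-4-yl on a saturated chain carbon bound to an oxygen on an aromatic ring and the change is (piperidin-4-yl)methyl in place of piperidin-4-yl on a saturated chain carbon bound to an oxygen on an aromatic ring.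

The same exchange has been measured once, without the methyl on the aromatic nitrogen, and it gave a 1.6-fold lower number from compound 1 to compound 2 (0.21 log units; within the scatter) as its step. The methyl itself gave a 1.2-fold higher number from compound 1 to compound 3 (0.06 log units; within the scatter) as its step. Both steps are small, but this single pair cannot show whether the chain exchange behaves alike with the methyl present. A small step in the same direction is therefore expected, with nothing beyond the scatter. The expected step is a 1.5-fold lower number from compound 3 to compound 4 (0.18 log units; within the scatter) in this assay on this reading. Compound 4 is estimated at 10 nM with an expected range from 5 nM to 20 nM in this assay when it is measured.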

Compound 4, half-maximal inhibitory concentration: 21 nM
Beside the measured number, compound 4's estimate is 2.1-fold (0.32 log units) below it, and the stated range ends below it.
By their numbers in this assay, from the lowest: compounds 2, 1, 3 and 4 (each within the scatter of the next, the first and the last beyond it).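

With the methyl on the aromatic nitrogen present, the exchange of piperidin-4-yl for (piperidin-4-yl)methyl in this assay gives a 1.4-fold higher number from compound 3 to compound 4 (0.15 log units; within the scatter), so the chain exchange now has a second reading, and neither reading leaves the scatter, nor do the two separate beyond it: the same change on two cores in this assay, a 1.6-fold lower number (0.21 log units; within the scatter) from compound 1 to compound 2 and a 1.4-fold higher number (0.15 log units; within the scatter) from compound 3 to compound 4, 2.3-fold (0.36 log units) apart, within the scatter of two such steps The methyl on the aromatic nitrogen, read on the 2-(piperidin-4-yl)ethoxy chain, gives a 2.6-fold higher number from compound 2 to compound 4 (0.42 log units; beyond the scatter), the only step among these compounds that passes beyond the scatter, though only modestly. Set against the methyl's step on the (piperidin-4-yl)methoxy chain, this does not show that the methyl counts for more on the 2-(piperidin-4-yl)ethoxy chain: the same change on two cores in this assay, a 1.2-fold higher number (0.06 log units; within the scatter) from compound 1 to compound 3 and a 2.6-fold higher number (0.42 log units; beyond the scatter) from compound 2 to compound 4, 2.3-fold (0.36 log units) apart, within the scatter of two such steps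

Among the compounds shown here, whether the chain and the methyl on the aromatic nitrogen truly depend on each other stays open, as each change is read on only two pairs. Also open, from the compounds shown here alone, is how this assay responds to a still longer chain carrying the piperidine ring, or to an ethyl group in place of the methyl on the aromatic nitrogen.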